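This account rests on a few compounds, and the source may have more. Where it says the series, first, only, none or still open, it means among the compounds named here.

Among the measured compounds shown here, compound 1 `S=C(N/N=C/c1ccc(Oc2ccc(Br)cc2)cc1)Nc1ccc(Cl)cc1` is the more lipophilic of the two compounds measured so far. In a physicochemical assay for lipophilicity, in phosphate buffer, measured as octanol-water partition, with a stated time of 24 h (a higher number here means a more lipophilic compound, a lower number a more polar compound), compound 1 gives 6.37. Its closest neighbour is compound 2 `Fc1ccc(NC(=S)N/N=C/c2ccc(Oc3ccc(Br)cc3)cc2)cc1`, and in this assay compound 2 gives 5.88. For the measured compounds named here, the one change between them, fluoro in place of chloro on an aromatic carbon, produced a number 0.49 log units lower from compound 1 to compound 2 (beyond the scatter).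

Compound 3 `Fc1ccc(Oc2ccc(/C=N/NC(=S)Nc3ccc(Cl)cc3)cc2)cc1` has not yet been measured. It differs from compound 1 at a different position: fluoro in place of bromo on an aromatic carbon. Going by the values given here, only one measured step bears on this change, the swap from compound 1 to compound 2, where a halogen on an aromatic carbon gave way to fluoro and the number fell by a modest amount, beyond the scatter. Among the compounds with values here, no measured step here concerns bromo giving way to fluoro, so that step is the only guide available. The expected change is therefore a lowering in this assay of roughly that size or somewhat more, estimated as a number 0.67 log units lower from compound 1 to compound 3 (beyond the scatter). For compound 3 the estimate in this assay is 5.7, with a likely range from 5.35 to 6.05.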

Compound 3, partition coefficient: 5.84
For compound 3 the middle estimate is 0.14 log units below the measured one, within the range that was stated.
By their numbers in this assay, from the lowest: compounds 3 and 2 (each within the scatter of the next); then compound 1.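

In this assay, the change from 4-bromophenoxy to 4-fluorophenoxy gives a number 0.53 log units lower from compound 1 to compound 3 (beyond the scatter), so this second halogen position on compound 1 also responds to a swap to fluoro. The earlier compounds shown here showed this kind of swap only at a different position, with chloro leaving, as a number 0.49 log units lower from compound 1 to compound 2 (beyond the scatter); the new step shows that the number moves in the same direction, by a modest amount in both cases, when bromo leaves instead. Nothing available here explains why the number moves with either change.

The compounds shown place only bromo and fluoro at this position on the six-membered aromatic ring, so the effect of an amine, a carboxylic acid or a longer chain such as propyl there remains open. They also leave open what this assay would show with fluoro at both halogen positions at once, and whether the two single steps would simply add up in such a compound.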